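Swapping the Aryl Ring: From Compound 3 to Compound 4

This account rests on a few compounds, and the source may have more. Where it says the series, first, only, none or still open, it means among the compounds named here.

Compound 1, `COc1cc(N2C(N)=C(C#N)C(c3ccccc3O)C3=C2CC(C)(C)CC3=O)cc(OC)c1OC`: 0%
Compound 2, `COc1ccccc1C1C(C#N)=C(N)N(c2cc(OC)c(OC)c(OC)c2)C2=C1C(=O)CC(C)(C)C2`: 65%
Compound 3, `COc1cc(N2C(N)=C(C#N)C(c3ccccc3Cl)C3=C2CC(C)(C)CC3=O)cc(OC)c1OC`: 15%

All three share one core and differ only in the ring attached to a saturated ring carbon. In a functional assay on Ehrlich cells (Mus musculus) for cytotoxicity, tested at 25 ug/mL (on this read-out higher numbers stand for a stronger effect at the one concentration tested and lower numbers for a weaker effect), compound 3 gives 15%, the second highest of the three: the step of a number 15 percentage points higher from compound 1 to compound 3 (beyond the scatter) lifts it above compound 1, while the step of a number 50 percentage points lower from compound 2 to compound 3 (beyond the scatter) leaves it well below compound 2. Compound 4, `COc1cc(N2C(N)=C(C#N)C(c3cccs3)C3=C2CC(C)(C)CC3=O)cc(OC)c1OC`, changes the same place: thiophen-2-yl in place of 2-chlorophenyl on a saturated ring carbon. Within the data shown here, no measured step exchanges the whole ring, and the two steps that touch this position pull in opposite directions with large and modest size, so the expected step of a number 10 percentage points higher from compound 3 to compound 4 (within the scatter) is uncertain in direction. Compound 4 is therefore estimated at 25%, within a wide range from 0% to 60%.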

Compound 4, a percentage reported as activity, at one concentration (the size of the read-out at that concentration, not a potency): 10%
Estimate against measurement, compound 4: 15 percentage points above; the measured number falls inside the stated range.
By their numbers in this assay, from the lowest: compounds 1, 4 and 3 (each within the scatter of the next, the first and the last beyond it); then compound 2.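

In this assay, thiophen-2-yl on this saturated ring carbon gives a number 5 percentage points lower from compound 3 to compound 4 (within the scatter) and a number 10 percentage points higher from compound 1 to compound 4 (within the scatter) and so cannot be told apart from either 2-chlorophenyl or 2-hydroxyphenyl. Against 2-methoxyphenyl it falls clearly short, with a number 55 percentage points lower from compound 2 to compound 4 (beyond the scatter) as the one large step here. No evidence at hand explains these numbers.

The compounds shown leave open whether a longer chain on the oxygen of compound 2, such as ethoxy, would hold its effect. They also leave open how a 2-aminophenyl ring at this carbon would compare.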